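The source may hold more compounds than are shown below. What is called first, only, known or untested is meant among the compounds shown, and "the series" means these compounds.

Three compounds share one core and differ in a halogen on the aromatic ring. Compound 1 `CCC(=O)N(c1cccc(F)c1)C1CCCC1N(C)C` carries a fluoro group; in a functional assay on the whole organism for positive allosteric modulation, with Mus musculus as the target (a lower number here means that less compound is needed, a higher number that more compound is needed for the effect), compound 1 gives 0.4 mg/kg. Compound 3 `CCC(=O)N(c1cccc(Br)c1)C1CCCC1N(C)C` carries a bromo group in place of that fluoro, the change being (bromo in place of fluoro on an aromatic carbon); the step is a 4.0-fold lower number from compound 1 to compound 3 (0.60 log units; beyond the scatter), and compound 3 gives 0.1 mg/kg. Compound 2 `CCC(=O)N(c1ccc(F)cc1)C1CCCC1N(C)C` has the same atoms as compound 1 joined differently, and the difference between the two cores is not broken down here; in this assay compound 2 gives 5 mg/kg, the highest of the three numbers.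

Compound 4 `CCC(=O)N(c1ccc(Br)cc1)C1CCCC1N(C)C` has not yet been measured. It differs from compound 2 by bromo in place of fluoro on an aromatic carbon, the same kind of change as that from compound 1 to compound 3, though the place is not the same: in compound 3 the bromo sits meta to a large group, in compound 4 para to a large group. Because the same kind of change made the step of a 4.0-fold lower number from compound 1 to compound 3 (0.60 log units; beyond the scatter), compound 4 is expected to give a step of a 3.3-fold lower number from compound 2 to compound 4 (0.52 log units; beyond the scatter), with less confidence since the place differs. In this assay compound 4 is estimated at 1.5 mg/kg, between 0.5 mg/kg and 5 mg/kg.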

Compound 4, dose for half-maximal effect: 2 mg/kg
For compound 4 the middle estimate is 1.3-fold (0.12 log units) below the measured one; low and high end bracket the measured number.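

On the core of compound 2, bromo in place of fluoro gives a 2.5-fold lower number from compound 2 to compound 4 (0.40 log units; beyond the scatter) in this assay. The step points the same way as the one on the core of compound 1, and the two steps cannot be told apart in size: the same change on two cores in this assay, a 4.0-fold lower number (0.60 log units; beyond the scatter) from compound 1 to compound 3 and a 2.5-fold lower number (0.40 log units; beyond the scatter) from compound 2 to compound 4, 1.6-fold (0.20 log units) apart, within the scatter of two such steps. So in this series the change carried over from one core to the other, but two pairs of compounds in a single assay do not show that it would carry over to any further core, and they do not explain why the number falls.

Fluoro and bromo are the only groups compared here, so it remains open whether chloro, iodo or a methyl group at the same place on the ring would fit the same picture. Going by these compounds, it also remains open whether the step would keep its direction and size if the amine or the amide chain of the shared core were changed, for instance to a longer chain.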